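The compounds below may be only part of what the source reports. "The series", "measured", "known", "first", "only" and "open" are said of these compounds alone.

Of the compounds shown here, three have been measured and a fourth awaits its number. In a functional assay on MCF7 cells (Homo sapiens) for cytotoxicity, read by MTT assay, with a stated time of 24 h (a lower number here means a stronger inhibitor, a higher number a weaker inhibitor), compound 1 `O=C1/C(=C/c2ccccc2F)CN(Cc2cn(Cc3ccccc3F)nn2)C/C1=C\c1ccccc1F` gives 6000 nM. Compound 2 `O=C1/C(=C/c2ccccc2F)CN(Cc2cn(Cc3ccccc3Cl)nn2)C/C1=C\c1ccccc1F` differs from compound 1 in one place, (chloro in place of fluoro on an aromatic carbon), and in this assay compound 2 gives 10000 nM, a step of a 1.7-fold higher number from compound 1 to compound 2 (0.22 log units; within the scatter). Compound 3 `Cc1ccc(/C=C2\CN(Cc3cn(Cc4ccccc4F)nn3)C/C(=C\c3ccc(C)cc3)C2=O)cc1` has a different core; how its core differs from that of compound 1 is not broken down here. In this assay compound 3 gives 28700 nM, the highest number of the three. Compound 4 `Cc1ccc(/C=C2\CN(Cc3cn(Cc4ccccc4Cl)nn3)C/C(=C\c3ccc(C)cc3)C2=O)cc1` relates to compound 3 by the same change, (chloro in place of fluoro on an aromatic carbon), at the same place. A step of about a 1.4-fold higher number from compound 3 to compound 4 (0.14 log units; within the scatter) is expected because a 1.7-fold higher number from compound 1 to compound 2 (0.22 log units; within the scatter) came from the same change. Compound 4 is therefore estimated at 40000 nM, between 18000 nM and 90000 nM.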

Compound 4, half-maximal inhibitory concentration: 66700 nM
Estimate against measurement, compound 4: 1.7-fold (0.22 log units) below, within the range that was stated.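

In this assay the exchange of 2-fluorobenzyl for 2-chlorobenzyl gives a 2.3-fold higher number from compound 3 to compound 4 (0.37 log units; beyond the scatter) on this second core, and the earlier step on the other core lies within the scatter. Two pairs in one assay show nothing about how the change would behave on any further core, and they do not explain the step. On these two cores the change carries over, with steps that do not differ in size: the same change on two cores in this assay, a 1.7-fold higher number (0.22 log units; within the scatter) from compound 1 to compound 2 and a 2.3-fold higher number (0.37 log units; beyond the scatter) from compound 3 to compound 4, 1.4-fold (0.14 log units) apart, within the scatter of two such steps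

The compounds shown hold only fluoro and chloro at this place on the benzyl ring. Going by these compounds, how a bromo, a methoxy or an amine would behave there remains open, as does a longer chain in place of the benzyl group.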